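The source may hold more compounds than are shown below. What is called first, only, known or untested is meant among the compounds shown, and "the series" means these compounds.

Working notes on the series. In an ADME assay on L6 cells (Rattus norvegicus) for cytotoxicity, read by resazurin assay, with a stated time of 72 h (on this read-out higher numbers stand for an effect only at larger amounts of compound and lower numbers for an effect already at smaller amounts), compound 1 (`CCOC(=O)C1=C(C)N/C(=C/c2cc(C)n(-c3cccc(C(F)(F)F)c3)c2C)C1=O`) gives 100000 nM and compound 2 (`CCOC(=O)C1=C(C)N/C(=C/c2cc(C)n(-c3ccc(CN4CCCCC4)cc3)c2C)C1=O`) gives 81000 nM. Compound 3 (`CCOC(=O)C1=C(C)N/C(=C/c2c(C)nn(-c3ccccc3)c2Cl)C1=O`) gives 13000 nM, the lowest of the three numbers and beyond the scatter from both of the others.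

Compound 4 (`CCOC(=O)C1=C(C)N/C(=C/c2c(C)nn(-c3ccc(C(F)(F)F)cc3)c2Cl)C1=O`) differs from compound 3 by trifluoromethyl in place of hydrogen on an aromatic carbon, para to a large group, so that phenyl becomes 4-(trifluoromethyl)phenyl.

Within the data shown here, no measured pair isolates this change, so its size in this assay can only be judged loosely. Compound 1 also bears a trifluoromethyl group and gives 100000 nM, but its core differs from that of compound 3, so it offers only a weak hint toward higher numbers. The expected step is a 1.5-fold higher number from compound 3 to compound 4 (0.19 log units; within the scatter), small and toward a higher number, and it may well stay within the scatter. For compound 4 the estimated value is 20000 nM, with an expected range of 7000 nM to 60000 nM.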

Compound 4, half-maximal effective concentration: 42000 nM
For compound 4 the middle estimate is 2.1-fold (0.32 log units) below the measured one; measured number inside the range.
By their numbers in this assay, from the lowest: compound 3; then compounds 4, 2 and 1 (each within the scatter of the next, the first and the last beyond it).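

In this assay, trifluoromethyl in place of hydrogen on an aromatic carbon, para to a large group, gives a 3.2-fold higher number from compound 3 to compound 4 (0.51 log units; beyond the scatter). Among these compounds, this is the first step that isolates a single change, and it shows that this position affects the read-out, with the effect now appearing only at larger amounts of compound. The step is modest and rests on one pair, so it cannot be carried over to the core of compound 1; nothing measured bears on what lies behind it.

Going by these compounds, it remains open whether this step is specific to trifluoromethyl or would also appear with a nitrile, a methoxy group or a carboxylic acid at this position. On these data alone, it is also open whether trifluoromethyl on another carbon of the same phenyl ring would give a step of similar size.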